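Removing one propyl group from compound 2

The source may report more compounds than this note shows. Statements on the series, on what has been measured and on what is new or still open speak of the compounds shown alone.

compound 1 `CC(C)NC(=S)N/N=C1\CC(c2ccc(O)cc2)Oc2cc(O)ccc21` gives 68100 nM
compound 2 `CCCN(CCC)C(=S)N/N=C1\CC(c2ccc(O)cc2)Oc2cc(O)ccc21` gives 75300 nM
compound 3 `CCCNC(=S)N/N=C1\CC(c2ccc(O)cc2)Oc2cc(O)ccc21` is not yet measured

Going by the values given here, in a functional assay on HeLa cells (Homo sapiens) for cytotoxicity, read by MTT assay, with a stated time of 72 h (on this read-out lower numbers stand for stronger inhibition and higher numbers for weaker inhibition), compound 2 gives 75300 nM and stands level with the only other measured compound, as a 1.1-fold higher number from compound 1 to compound 2 (0.04 log units; within the scatter) shows. Going on to compound 3 brings hydrogen in place of propyl on an amide-type nitrogen in all: hydrogen in place of propyl on an amide-type nitrogen. Among the compounds with values here, no measured step removes a propyl group alone. The nearest evidence is a 1.1-fold higher number from compound 1 to compound 2 (0.04 log units; within the scatter) on the same nitrogen, so no change beyond the scatter is expected in this assay for this step. The expected size is a 1.1-fold lower number from compound 2 to compound 3 (0.03 log units; within the scatter) as estimated here. Compound 3 is estimated at 70000 nM with an expected range from 40000 nM to 120000 nM in this test.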

Compound 3, half-maximal inhibitory concentration: 40200 nM
For compound 3 the middle estimate is 1.7-fold (0.24 log units) above the measured one; the measured number falls inside the stated range.
By their numbers in this assay, from the lowest: compounds 3, 1 and 2 (each within the scatter of the next).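

In this assay, taking away one propyl group gives a 1.9-fold lower number from compound 2 to compound 3 (0.27 log units; within the scatter), and moving from a branched to a straight chain gives a 1.7-fold lower number from compound 1 to compound 3 (0.23 log units; within the scatter). Both steps stay within the scatter, so dipropylamino, propylamino and isopropylamino on this thiocarbonyl carbon cannot be told apart in this test. No supporting data bear on this result. As far as these compounds go, these three compounds carry only small alkyl groups at this nitrogen, so it remains open whether a longer chain such as octyl, a phenyl ring or a carboxylic acid would give a number beyond the scatter.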